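Swapping the aryl on a weak compound: expecting little change

The source may report more compounds than this note shows. Statements on the series, on what has been measured and on what is new or still open speak of the compounds shown alone.

Measured compounds:
Compound 1, `O=C(Nc1ccc(Oc2ccc(-c3nccs3)cc2)cc1)Nc1ccc(Cl)c([N+](=O)[O-])c1`, gives 72.8% in a functional assay on MDA-MB-231 cells (Homo sapiens) for inhibition, read by MTT assay and WST assay, with a stated time of 72 h, tested at 10 uM; a higher number here means more inhibition of growth at the concentration tested, a lower number less inhibition of growth.
Compound 2, `O=C(Nc1ccc(Oc2ccc(-c3nccs3)cc2)cc1)Nc1ccc(F)c(Cl)c1`, gives 43.9% in this assay.
Compound 3, `O=C(Nc1ccc(Oc2ccc(-c3ncc[nH]3)cc2)cc1)Nc1ccc(Cl)c([N+](=O)[O-])c1`, gives 3.36% in this assay.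

Compound 3 stands lowest of the three numbers in this assay; the nearest is compound 2, and compound 1 lies furthest away, both beyond the scatter. Compound 4, `CC(=O)Oc1sccc1NC(=O)Nc1ccc(Oc2ccc(-c3ncc[nH]3)cc2)cc1`, has not yet been measured. It differs from compound 3 in one place: 2-acetoxythiophen-3-yl in place of 4-chloro-3-nitrophenyl on an amide-type nitrogen.

For the measured compounds named here, two measured steps bear on this. The step of a number 28.9 percentage points lower from compound 1 to compound 2 (beyond the scatter) changed the group on the same amide-type nitrogen and was modest. The step of a number 69.4 percentage points lower from compound 1 to compound 3 (beyond the scatter), exchanging 1,3-thiazol-2-yl for 1H-imidazol-2-yl, was large, and compound 4 keeps the 1H-imidazol-2-yl of compound 3. Since compound 3 already sits near the bottom of the scale, a new aryl on the amide-type nitrogen is expected to move it by at most a modest amount, if at all beyond the scatter, with no clear direction. For compound 4 the step of a number 2.6 percentage points higher from compound 3 to compound 4 (within the scatter) is therefore expected, giving an estimated value of 6%, ranging from -10% to 25%.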

Compound 4, percent growth inhibition at one concentration: -1.46%
For compound 4 the middle estimate is 7.5 percentage points above the measured one, within the range that was stated.
By their numbers in this assay, from the lowest: compounds 4 and 3 (each within the scatter of the next); then compound 2; then compound 1.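

In this assay, the step of a number 4.8 percentage points lower from compound 3 to compound 4 (within the scatter) shows that, with 1H-imidazol-2-yl in the molecule, exchanging 4-chloro-3-nitrophenyl for 2-acetoxythiophen-3-yl on the amide-type nitrogen gives no measurable change, even though a nitro-bearing six-membered ring gives way to a five-membered ring with a sulfur atom. This differs from the step of a number 28.9 percentage points lower from compound 1 to compound 2 (beyond the scatter), a different exchange on the same nitrogen with 1,3-thiazol-2-yl present, which lay beyond the scatter. No measurement shown here accounts for this contrast.

Going by these compounds, since compound 3 and compound 4 both sit near the bottom of the scale, it remains open how 2-acetoxythiophen-3-yl would perform alongside 1,3-thiazol-2-yl. Also open, on these data alone, is what an amine or a carboxylic acid on the aryl group at this nitrogen would do.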